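The compounds below may be only part of what the source reports. "The series", "measured", "known", "first", "only" and "open" are said of these compounds alone.

Measured compounds:
compound 1, `O=C(Nc1nn[nH]n1)c1cc(Cl)cc(-c2ccccc2)n1`, in a functional assay on the whole organism with Rattus norvegicus as the target, at a dose of 1 mg/kg by the oral route (on this read-out higher numbers stand for a stronger effect at the one dose given and lower numbers for a weaker effect), gives 40%
compound 2, `COc1ccc(-c2cc(Cl)cc(C(=O)Nc3nn[nH]n3)n2)cc1`, gives 43%
compound 3, `COc1cc(C(=O)Nc2nn[nH]n2)nc(-c2ccc(Cl)cc2)c1`, gives 0%

Compound 3 stands lowest of the three numbers, beyond the scatter below both compound 1 and compound 2. Compound 4, `CCc1ccc(-c2cc(OC)cc(C(=O)Nc3nn[nH]n3)n2)cc1`, is not yet measured; it differs from compound 3 by ethyl in place of chloro on an aromatic carbon, the same difference read one bond further out as 4-chlorophenyl to 4-ethylphenyl. Within the data shown here, the only measured step, a number 3 percentage points higher from compound 1 to compound 2 (within the scatter), concerns a different change and lies within the scatter, so no measured step bears on ethyl in place of chloro. The expectation for compound 4 therefore rests on compound 3 alone, with no shown step to move it. Compound 4 is expected to give 8%, between 0% and 30%. This estimate means a step of a number 8 percentage points higher from compound 3 to compound 4 (within the scatter), expected to stay within the scatter.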

Compound 4, a percentage reported as inhibition, in the whole organism at one dose (the size of the read-out at that dose, not a potency): 43%
Compound 4: middle estimate off by 35 percentage points, on the low side, and the stated range ends below it.
By their numbers in this assay, from the lowest: compound 3; then compounds 1, 2 and 4 (each within the scatter of the next).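

In this assay, ethyl in place of chloro on an aromatic carbon, para to a large group, gives a number 43 percentage points higher from compound 3 to compound 4 (beyond the scatter) and so changes the outcome at this position. The lack of effect of compound 3 at 0% is therefore not fixed by the rest of its structure, since this one change is enough to bring the read-out up. Nothing measured here accounts for the step. On these data alone, it remains open whether a longer chain such as propyl, or an amine, would work at this position. As far as these compounds go, it also remains open whether ethyl would give a similar step on the core of compound 1.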